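From Methoxy to Trifluoromethoxy at the Assay Limit

The source may report more compounds than this note shows. Statements on the series, on what has been measured and on what is new or still open speak of the compounds shown alone.

Of the compounds shown here, three sharing one core have been measured so far in a functional assay on A549 cells (Homo sapiens) for inhibition (on this read-out higher numbers stand for weaker inhibition and lower numbers for stronger inhibition), on this read-out. Compound 1 `CC(=O)Oc1ccc(/C=C/c2ccc3ccccc3c2)cc1` carries acetyl on an oxygen on an aromatic ring and gives > 5000 nM as a limit and not a number. Among the compounds with values here, compound 2 `Oc1ccc(/C=C/c2ccc3ccccc3c2)cc1` has hydrogen in that place and gives 4060 nM as the only true number of the set. Compound 3 `COc1ccc(/C=C/c2ccc3ccccc3c2)cc1` has methyl there and gives > 5000 nM as a limit too. Compound 3 thus has no number of its own (the limit of > 5000 nM in this assay, at which 2 of the 3 values shown sit).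

Compound 4 `FC(F)(F)Oc1ccc(/C=C/c2ccc3ccccc3c2)cc1` alters this one group of compound 3 (trifluoromethyl in place of methyl on an oxygen on an aromatic ring) by placing trifluoromethyl in place of methyl on an oxygen on an aromatic ring. Three measured steps at this same oxygen bear on the change. One is an at least 1.2-fold lower number from compound 1 to compound 2 (0.09 log units; that floor lies within the scatter) and another is an at least 1.2-fold higher number from compound 2 to compound 3 (0.09 log units; that floor lies within the scatter) while the third is a step that the two limits leave unreadable from compound 1 to compound 3 and gives no size. None of them involves trifluoromethyl, and none reads beyond the scatter. No step beyond the scatter is therefore expected in this assay for this change. The estimated step is a number no higher from compound 3 to compound 4 (the limit leaves the size open) with no firm direction. Compound 4 is expected near 5000 nM with an estimated range from 2500 nM to 10000 nM and may well turn out only as a limit.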

Compound 4, half-maximal inhibitory concentration: > 5000 nM
Compound 4 gave a limit, no number; the forecaster's own chance of this, stated with the estimate: 65%; the middle value sits exactly at the limit.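

In this assay compound 4 gives > 5000 nM, which is a limit and not a number, so trifluoromethyl joins acetyl and methyl on this oxygen at the same ceiling of the read-out: the limit of > 5000 nM in this assay, at which 3 of the 4 values shown sit. The only step that can be read at all is an at least 1.2-fold higher number from compound 2 to compound 4 (0.09 log units; that floor lies within the scatter), and it gives a floor, not a size, so even the exchange of hydrogen for trifluoromethyl on this oxygen is not shown to go beyond the scatter. The steps linking compound 4 to compound 3 and to compound 1 cannot be read, as each has a limit at both ends.

The compounds shown leave open how far methyl, trifluoromethyl and acetyl on this oxygen stand from one another, and whether any of them truly differs from hydrogen by more than the scatter. They also leave open how a longer chain on this oxygen, or such a chain ending in an amine or a carboxylic acid, would read in this assay.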